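The source may report more compounds than this note shows. Statements on the series, on what has been measured and on what is new or still open speak of the compounds shown alone.

Measured so far in an ADME assay on MT4 cells (Homo sapiens) for cytotoxicity, read by MTT assay, with a stated time of 5 days; on this read-out higher numbers stand for lower toxicity in this test and lower numbers for higher toxicity in this test:
- compound 1, `O=C1CSC(c2ccccc2Cl)N1c1nnc(S)s1`: 200000 nM
- compound 2, `NS(=O)(=O)c1ccc(NC(=O)CSc2nnc(N3C(=O)CSC3c3ccccc3)s2)cc1`: 99200 nM
- compound 3, `NS(=O)(=O)c1ccc(NC(=O)CSc2nnc(N3C(=O)CSC3c3ccccc3Cl)s2)cc1`: >= 18800 nM (a limit of the assay, not a number)

For compound 3 only a limit is known in this assay, so it cannot be placed against compound 1 or compound 2 beyond that limit. Compound 1 and compound 2 both give full numbers; their values are shown above and no step between them is computed here.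

Compound 4, `CS(=O)(=O)c1ccc(NC(=O)CSc2nnc(N3C(=O)CSC3c3ccccc3Cl)s2)cc1`, is not yet measured. It differs from compound 3 by methyl in place of amino on a sulfonyl sulfur.

For the measured compounds named here, the only measured step that touches the sulfamoyl-bearing scaffold is a step that the limit leaves unreadable from compound 2 to compound 3; its size is not readable, because the limit of >= 18800 nM in this assay, at which 1 of the 3 values shown sits, is where compound 3 sits. Going by the values given here, no measured step changes the sulfonyl substituent itself, so there is no direct precedent for the methyl-for-amino exchange.

With compound 3 known only as a limit, the expectation for compound 4 is a step that the limit leaves unreadable from compound 3 to compound 4 in this assay, that is no change beyond the scatter, and a fair chance that compound 4 again returns only a limit. Compound 4 is therefore estimated at 40000 nM, within a range from 15000 nM to 200000 nM.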

Compound 4, half-maximal cytotoxic concentration: >= 172000 nM
Compound 4 ended at the assay's limit; the forecaster's own chance of this, stated with the estimate: 55%; middle value at least 4.3-fold (0.63 log units) from the limit.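

In this assay compound 4 gives >= 172000 nM, a limit of the assay and not a number. Compound 3 gives >= 18800 nM, also a limit. For the compounds shown here, no step from compound 3 to compound 4 can be read. The compounds shown leave open what size of change, if any, methyl in place of amino on a sulfonyl sulfur produces.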